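A few compounds are considered here, and "the series" means these few. Any claim that something is new, unique, unknown or untested is made for them only; others in the source may bear on it.

Three measured compounds share one core and differ only in the ring attached to it. Compound 1 `Cc1nc(C)c(CN2CCN(c3cccc4[nH]c(-c5ccc(C(C)(C)C)cc5)nc34)CC2)s1` gives 27 nM in an assay on isolated protein for displacement of a labelled ligand from Gonadotropin-releasing hormone receptor (Homo sapiens); a lower number here means a stronger inhibitor, a higher number a weaker inhibitor. Compound 2 `CCc1nc(C)c(CN2CCN(c3cccc4[nH]c(-c5ccc(C(C)(C)C)cc5)nc34)CC2)s1` carries methyl in place of hydrogen on a saturated chain carbon bound to an aromatic carbon and gives 20 nM, a step of a 1.4-fold lower number from compound 1 to compound 2 (0.13 log units; within the scatter). Compound 3 `CCn1cc(CN2CCN(c3cccc4[nH]c(-c5ccc(C(C)(C)C)cc5)nc34)CC2)nc1C` carries another ring, (1-ethyl-2-methyl-1H-imidazol-4-yl in place of 2,4-dimethyl-1,3-thiazol-5-yl on a saturated chain carbon bound to an amine nitrogen in a ring), and gives 10 nM; the step of a 2.7-fold lower number from compound 1 to compound 3 (0.43 log units; beyond the scatter) is modest, while a 2.0-fold lower number from compound 2 to compound 3 (0.30 log units; within the scatter).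

Compound 4 `CCCn1cc(CN2CCN(c3cccc4[nH]c(-c5ccc(C(C)(C)C)cc5)nc34)CC2)nc1C` has not been measured. It differs from compound 3 by methyl in place of hydrogen on a saturated chain carbon, two bonds along the chain from an aromatic nitrogen, the same kind of change as that from compound 1 to compound 2, though there the methyl sits on a saturated chain carbon bound to an aromatic carbon and here on a saturated chain carbon two bonds along the chain from an aromatic nitrogen. For compound 4 a similar small step is expected, a 1.3-fold lower number from compound 3 to compound 4 (0.10 log units; within the scatter), because the step of a 1.4-fold lower number from compound 1 to compound 2 (0.13 log units; within the scatter) stayed within the scatter. Compound 4 is estimated at 8 nM, between 3 nM and 20 nM.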

Compound 4, half-maximal inhibitory concentration: 18 nM
Beside the measured number, compound 4's estimate is 2.3-fold (0.35 log units) below it; the range from low to high includes it.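

The change from ethyl to propyl gives a 1.8-fold higher number from compound 3 to compound 4 (0.26 log units; within the scatter) in this assay, and this step cannot be told apart from the earlier step of adding a methyl to a chain: the same change on two cores in this assay, a 1.4-fold lower number (0.13 log units; within the scatter) from compound 1 to compound 2 and a 1.8-fold higher number (0.26 log units; within the scatter) from compound 3 to compound 4, 2.4-fold (0.39 log units) apart, within the scatter of two such steps. Exchanging the thiazole ring for 2-methyl-1-propyl-1H-imidazol-4-yl also stays small, with a 1.1-fold lower number from compound 2 to compound 4 (0.05 log units; within the scatter) and a 1.5-fold lower number from compound 1 to compound 4 (0.18 log units; within the scatter) as the two steps. On these two cores, then, the added methyl gives no step beyond the scatter, but two pairs show neither a direction for the step nor that it would stay this small on a third core.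

The compounds shown leave open what a longer chain such as butyl would do. They also leave open the effect of an amine or a carboxylic acid at the end of the chain.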